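Benzyloxy ring substituents on the phosphatase series

A few compounds are considered here, and "the series" means these few. Any claim that something is new, unique, unknown or untested is made for them only; others in the source may bear on it.

Measured compounds:
compound 1 `CN1C(=O)/C(=C/c2ccc(OCc3ccc(F)cc3)cc2)S/C1=N/c1cccc(C(=O)O)c1`, 26900 nM in an assay for inhibition of dual specificity protein phosphatase 26 (Homo sapiens), read by fluorescence, with a stated time of 30 min; a higher number here means a weaker inhibitor, a lower number a stronger inhibitor
compound 2 `CN1C(=O)/C(=C/c2ccc(OCc3cccc([N+](=O)[O-])c3)cc2)S/C1=N/c1cccc(C(=O)O)c1`, 19800 nM in this assay

Compound 2 holds the lowest number of the two, with compound 1 nearest; the gap between them is a 1.4-fold lower number from compound 1 to compound 2 (0.13 log units; within the scatter). Compound 3 `CN1C(=O)/C(=C/c2ccc(OCc3cccc(F)c3)cc2)S/C1=N/c1cccc(C(=O)O)c1` differs from compound 2 by fluoro in place of nitro on an aromatic carbon. Among the measured compounds shown here, the only step that bears on it, 3-nitrophenyl in place of 4-fluorophenyl, stayed within the scatter, and compound 1 with its fluoro carries a number close to compound 2. Compound 3 is therefore expected to move by a 1.2-fold higher number from compound 2 to compound 3 (0.08 log units; within the scatter), no more than the scatter. The estimate for compound 3 in this assay is 24000 nM, in the range 10000 nM to 60000 nM.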

Compound 3, half-maximal inhibitory concentration: 12500 nM
The estimate for compound 3 lay 1.9-fold (0.28 log units) above the measured number, within the range that was stated.
By their numbers in this assay, from the lowest: compounds 3, 2 and 1 (each within the scatter of the next, the first and the last beyond it).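

In this assay, among the compounds shown here, moving the fluoro from 4-fluorophenyl to 3-fluorophenyl gives a 2.2-fold lower number from compound 1 to compound 3 (0.33 log units; beyond the scatter) and is the first modest step beyond the scatter. With the 3-substituted ring kept, fluoro in place of nitro gives a 1.6-fold lower number from compound 2 to compound 3 (0.20 log units; within the scatter) and does not separate the two compounds. No supporting data explain either step.

Still open, from the compounds shown here alone, is how an amine or a methoxy group in place of the fluoro on the 3-substituted ring would read in this assay. A longer chain in place of the benzyl carbon also remains untested among the compounds shown.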